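Switching the aryl group of compound 3 to the bromoindolyl

The source may report more compounds than this note shows. Statements on the series, on what has been measured and on what is new or still open speak of the compounds shown alone.

Among the compounds with values here, compound 3 `CSc1ccc(/C=C(/SCc2ccc(C)cc2)C(=O)c2ccc(Cl)cc2)cc1` gives 25000 nM in a functional assay on DU-145 cells (Homo sapiens) for inhibition, read by trypan blue exclusion, with a stated time of 96 h (a lower number here means a stronger inhibitor of growth, a higher number a weaker inhibitor of growth), the lowest of the three numbers so far, yet both neighbours sit within the scatter: compound 1 `O=C(/C(=C\c1c[nH]c2ccc(Br)cc12)SCc1ccc(F)cc1)c1ccc(Cl)cc1` gives 50000 nM and compound 2 `Cc1ccc(CS/C(=C/c2ccc(O)c(O)c2O)C(=O)c2ccc(Cl)cc2)cc1` gives 50000 nM. Compound 4 `Cc1ccc(CS/C(=C/c2c[nH]c3ccc(Br)cc23)C(=O)c2ccc(Cl)cc2)cc1` differs from compound 3 by 5-bromo-1H-indol-3-yl in place of 4-(methylsulfanyl)phenyl on a double-bonded chain carbon bound to a double-bonded chain carbon. Within the data shown here, the only step at this place is a 2.0-fold lower number from compound 2 to compound 3 (0.30 log units; within the scatter), a different swap and within the scatter, so it says little about the present change. Compound 1, which already carries the 5-bromo-1H-indol-3-yl group, shows a number close to that of compound 3. No step beyond the scatter is therefore expected for compound 4, a 1.6-fold higher number from compound 3 to compound 4 (0.20 log units; within the scatter). Compound 4 is estimated at 40000 nM, within 15000 nM to 100000 nM.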

Compound 4, concentration for 50% growth inhibition: 1000 nM
The estimate for compound 4 lay 40-fold (1.60 log units) above the measured number, outside the stated range (below it).
By their numbers in this assay, from the lowest: compound 4; then compounds 3, 1 and 2 (each within the scatter of the next).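

In this assay the place on a double-bonded chain carbon bound to a double-bonded chain carbon proves sensitive: 5-bromo-1H-indol-3-yl gives large steps against 4-(methylsulfanyl)phenyl (a 25-fold lower number from compound 3 to compound 4 (1.40 log units; beyond the scatter)) and against 2,3,4-trihydroxyphenyl (a 50-fold lower number from compound 2 to compound 4 (1.70 log units; beyond the scatter)). That group does not suffice alone, as methyl in place of fluoro on an aromatic carbon also gives a large step (a 50-fold lower number from compound 1 to compound 4 (1.70 log units; beyond the scatter)). Nothing measured here accounts for these steps.

Open, from the compounds shown here alone, is whether the bromine is needed, as a chloro or hydrogen there would show. Also open, going by these compounds, is whether an ethyl or methoxy group in place of the methyl keeps the low number.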